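Dichlorophenyl to Dimethoxyphenyl on a Side Arm

The compounds below may be only part of what the source reports. "The series", "measured", "known", "first", "only" and "open" are said of these compounds alone.

Among the measured compounds shown here, compound 1 `Nc1cc(N)c2nc(-c3ccccc3)c(NCc3ccc(Cl)c(Cl)c3)nc2c1` gives 4470 nM in a functional assay on MDA-MB-231 cells (Homo sapiens) for inhibition, read by sulforhodamine B assay, with a stated time of 48 h (on this read-out lower numbers stand for stronger inhibition of growth and higher numbers for weaker inhibition of growth), the lowest of the three numbers measured so far. Compound 2 `CCOC(=O)[C@H](CCC(=O)O)NC(=O)c1ccc(Sc2nc3cc(N)cc(N)c3nc2-c2ccccc2)cc1` gives 35500 nM in this assay, and compound 3 `Nc1cc(N)c2nc(-c3ccccc3)c(Sc3ccc(Cl)c(Cl)c3)nc2c1` gives 53700 nM; both gaps from compound 1 lie beyond the usual scatter. Compound 4 `COc1ccc(CNc2nc3cc(N)cc(N)c3nc2-c2ccccc2)cc1OC` has not yet been measured. It differs from compound 1 in one place: 3,4-dimethoxyphenyl in place of 3,4-dichlorophenyl on a saturated chain carbon bound to a nitrogen on an aromatic ring. For the measured compounds named here, no measured pair shows this kind of swap, so there is no direct precedent, and the change is expected to shift the number only modestly, most likely toward weaker inhibition of growth. The step is estimated at a 1.8-fold higher number from compound 1 to compound 4 (0.25 log units; within the scatter). Compound 4 is therefore expected to give about 8000 nM, within a range from 2500 nM to 25000 nM.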

Compound 4, concentration for total growth inhibition: 29500 nM
Estimate against measurement, compound 4: 3.7-fold (0.57 log units) below; measured number above the stated range.
By their numbers in this assay, from the lowest: compound 1; then compounds 4, 2 and 3 (each within the scatter of the next).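

Among the compounds shown here, this is the first change in one place only, and it shows that the groups on this phenyl ring matter: in this assay, 3,4-dimethoxyphenyl in place of 3,4-dichlorophenyl gives a 6.6-fold higher number from compound 1 to compound 4 (0.82 log units; beyond the scatter). On a saturated chain carbon bound to a nitrogen on an aromatic ring, 3,4-dichlorophenyl is thus the better of these two groups. Nothing at hand tells why the number rises. Still open, from the compounds shown here alone, is whether a single methoxy, a single chlorine, a trifluoromethyl or an amine on this phenyl ring would match compound 1 or improve on it.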